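Taking the chloro away from compound 2

The compounds below may be only part of what the source reports. "The series", "measured", "known", "first", "only" and "open" are said of these compounds alone.

In a physicochemical assay for solubility, read by nephelometry, measured as kinetic solubility, at pH 2, tested at 10 mg/mL (a higher number here means a more soluble compound, a lower number a less soluble compound), compound 1 (`Cc1ccccc1C(=O)Nc1cc(Cl)ccn1`) gives 25 ug/mL. Compound 2 (`Cc1c(F)cccc1C(=O)Nc1cc(Cl)ccn1`) gives 12.5 ug/mL, so the two numbers lie within the scatter of each other. The fluoro that separates them makes a 2.0-fold lower number from compound 1 to compound 2 (0.30 log units; within the scatter), and that is within the scatter. Compound 3 (`Cc1ccccc1C(=O)Nc1cccc(F)n1`) gives > 100 ug/mL, which is a limit of the assay and not a number.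

Compound 4 (`Cc1c(F)cccc1C(=O)Nc1ccccn1`) comes from compound 2 through hydrogen in place of chloro on an aromatic carbon, opposite the ring nitrogen. Among the compounds with values here, no measured step makes this change. Within the data shown here, the single step available, a 2.0-fold lower number from compound 1 to compound 2 (0.30 log units; within the scatter), lies elsewhere in the structure and offers no guide to size. An upward expectation rests only on compound 3, which carries no chloro and shows > 100 ug/mL. That compound also differs in other places, so the size of the step remains uncertain. The expected change is a 4.0-fold higher number from compound 2 to compound 4 (0.60 log units; beyond the scatter), an estimate that goes beyond the scatter only modestly. Compound 4 is estimated at 50 ug/mL, with an expected range from 20 ug/mL to 100 ug/mL in this assay.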

Compound 4, solubility: 50 ug/mL
Compound 4: the middle estimate sits on the measured number at the digits printed; low and high end bracket the measured number.
By their numbers in this assay, from the lowest: compounds 2, 1 and 4 (each within the scatter of the next, the first and the last beyond it). At a limit, above all of these: compound 3.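

In this assay, hydrogen in place of chloro, opposite the ring nitrogen, gives a 4.0-fold higher number from compound 2 to compound 4 (0.60 log units; beyond the scatter), a modest step. Within the data shown here, the only earlier step, fluoro in place of hydrogen, gave a 2.0-fold lower number from compound 1 to compound 2 (0.30 log units; within the scatter), so this position is the first at which a single change to the shared core is seen to move the read-out beyond the scatter. The change is read on one pair only, and in that pair the fluoro is present on both sides.

On these data alone, whether the same step appears without that fluoro, and where an amine or a methoxy group at this position would fall relative to compound 2 and compound 4, stays open. Compound 3 stands at a limit and not at a number, so it cannot size any such change: the limit of > 100 ug/mL in this assay, at which 1 of the 4 values shown sits.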